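Amide in place of amine on the macrocyclic ring

A few compounds are considered here, and "the series" means these few. Any claim that something is new, unique, unknown or untested is made for them only; others in the source may bear on it.

Two analogues sharing one core have been measured. In a functional assay on HL-60 cells (Homo sapiens) for antiproliferative activity, read by MTT assay, with a stated time of 48 h (on this read-out lower numbers stand for stronger inhibition and higher numbers for weaker inhibition), compound 1 `CC(C)=CCC[C@]1(C)/C=C/[C@@H](OC(=O)C=C(C)C)[C@](C)(O)/C=C/C(=O)/C(CN2CCCC2)=C\C1` gives 160 nM, and compound 2 `CC(C)=CCC[C@]1(C)/C=C/[C@@H](OC(=O)C=C(C)C)[C@](C)(O)/C=C/C(O)/C(C=O)=C\C1` gives 240 nM; the two numbers lie within the usual scatter of each other, so neither compound can be set apart on this assay. Compound 3 `CC(C)=CCC[C@]1(C)/C=C/[C@@H](OC(=O)C=C(C)C)[C@](C)(O)/C=C/C(=O)/C(C(=O)N2CCCC2)=C\C1` has not yet been measured. It differs from compound 1 by (pyrrolidin-1-yl)carbonyl in place of (pyrrolidin-1-yl)methyl on a double-bonded ring carbon. For the measured compounds named here, no measured pair shows this kind of change, so any step in this assay from compound 1 to compound 3 is expected to be modest, at most a small weakening. Compound 3 is expected to give 300 nM, within 100 nM to 1000 nM, a step of a 1.9-fold higher number from compound 1 to compound 3 (0.27 log units; within the scatter).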

Compound 3, half-maximal inhibitory concentration: 12300 nM
Compound 3: the middle estimate sits 41-fold (1.61 log units) below what was measured; measured number above the stated range.
By their numbers in this assay, from the lowest: compounds 1 and 2 (each within the scatter of the next); then compound 3.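

In this assay, (pyrrolidin-1-yl)carbonyl in place of (pyrrolidin-1-yl)methyl on this double-bonded ring carbon gives a 77-fold higher number from compound 1 to compound 3 (1.89 log units; beyond the scatter). This shows that the position is sensitive to the link joining the pyrrolidine ring to the shared core, even though both groups carry that ring and the same printed counts of hydrogen-bond donors and acceptors. Nothing available here accounts for the size of this step. As far as these compounds go, it remains open whether another amine on the same methylene link, such as (piperidin-1-yl)methyl or (morpholin-4-yl)methyl, would stay close to compound 1 in this assay.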